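Shortening the chain on compound 1: allyl to hydrogen

A few compounds are considered here, and "the series" means these few. Any claim that something is new, unique, unknown or untested is made for them only; others in the source may bear on it.

Going by the values given here, compound 1, `C=CCCn1c(=O)c2[nH]cnc2n(CCC)c1=O`, holds the lowest number of the three measured members: in a functional assay (trachea) with Cavia porcellus as the target (on this read-out higher numbers stand for an effect only at larger amounts of compound and lower numbers for an effect already at smaller amounts), compound 1 gives 200 nM. Compound 2, `CCCn1c(=O)n(CCCO)c(=O)c2[nH]cnc21`, gives 5100 nM in this assay, and compound 3, `CCCn1c(=O)n(CCOC)c(=O)c2[nH]cnc21`, gives 700 nM. Both measured steps away from compound 1 go upward: a 26-fold higher number from compound 1 to compound 2 (1.41 log units; beyond the scatter) and a 3.5-fold higher number from compound 1 to compound 3 (0.54 log units; beyond the scatter), while a 7.3-fold lower number from compound 2 to compound 3 (0.86 log units; beyond the scatter) separates the two replacements from each other.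

Compound 4, `CCCn1c(=O)n(C)c(=O)c2[nH]cnc21`, differs from compound 1 by hydrogen in place of allyl on a saturated chain carbon bound to an aromatic nitrogen. Among the compounds with values here, no measured pair shows this change itself; the measured steps alter the outer end of the same chain and leave its length, whereas here the chain is cut back to a methyl. What the two measured steps do show is that any departure from the vinyl end on this chain raised the number in this assay, by a modest to large amount.

Expected for compound 4 in this assay is therefore a rise of roughly a 10-fold higher number from compound 1 to compound 4 (1.00 log units; beyond the scatter), in the same direction as the two measured departures from compound 1. Compound 4 is estimated at 2000 nM, with a range from 500 nM to 8000 nM.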

Compound 4, half-maximal effective concentration: 1600 nM
Estimate against measurement, compound 4: 1.3-fold (0.10 log units) above; measured number inside the range.
By their numbers in this assay, from the lowest: compound 1; then compound 3; then compound 4; then compound 2.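

Replacing the whole allyl group with hydrogen, rather than changing only the end of the chain, also costs activity in this assay: the step is an 8.0-fold higher number from compound 1 to compound 4 (0.90 log units; beyond the scatter), so the low number of compound 1 depends on a group being present at this place, on a saturated chain carbon bound to an aromatic nitrogen. Yet the bare methyl does not mark the top of the series: with a 3.2-fold lower number from compound 2 to compound 4 (0.50 log units; beyond the scatter), the 2-hydroxyethyl group stands above hydrogen on this read-out, while with a 2.3-fold higher number from compound 3 to compound 4 (0.36 log units; beyond the scatter), the methoxymethyl group stands below it, so extending the chain from methyl can move the number either way, depending on the group added. Nothing at hand gives a reason for this order.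

Still open, from the compounds shown here alone, is whether a plain propyl group in place of allyl would keep the number of compound 1, which would separate the length of the chain from its double bond. Equally open, going by these compounds, is how a longer chain, or an amine or a carboxylic acid at the chain end, would fall relative to hydrogen in this assay on this core.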